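Diaryl-alkene series: methoxycarbonyl in place of ethyl

The compounds below may be only part of what the source reports. "The series", "measured", "known", "first", "only" and "open" are said of these compounds alone.

Measured so far:
compound 1 `CCOc1cc(C(=CC#N)c2ccc(OC)c(F)c2)ccc1OC` — 130 nM
compound 2 `CCC=C(c1cc(OC)cc(OC)c1)c1ccc(OC)c(OC)c1` — > 10000 nM
compound 3 `COc1cc(OC)cc(C(=CC#N)c2ccc(OC)c(O)c2)c1` — 2.5 nM

In a functional assay on HCT-116 cells (Homo sapiens) for cytotoxicity, read by scintillation counting and thymidine incorporation, with a stated time of 72 h (on this read-out higher numbers stand for weaker inhibition and lower numbers for stronger inhibition), compound 1 gives 130 nM and compound 3 gives 2.5 nM. For compound 2 this assay reports only a limit, > 10000 nM. Compound 2 thus stands at the weak end of the three results, at the limit of > 10000 nM in this assay, at which 1 of the 3 values shown sits, and its true value is not known. The two compounds with a nitrile on the chain carry the measurable numbers; compound 2 carries an ethyl there.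

Compound 4 `COC(=O)C=C(c1cc(OC)cc(OC)c1)c1ccc(OC)c(OC)c1` is the untested analogue. Relative to compound 2 the change is methoxycarbonyl in place of ethyl on a double-bonded chain carbon bound to a double-bonded chain carbon. Going by the values given here, no pair of measured compounds differs in one place, so no measured step anchors the size of this change. Since compound 2 is only a limit, any step from it is bounded on one side only. The expectation is a move toward stronger inhibition in this assay, of a size beyond the scatter, given as an at least 5.0-fold lower number from compound 2 to compound 4 (0.69 log units; beyond the scatter). Compound 4 is estimated at 2000 nM, with a range from 300 nM to 10000 nM.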

Compound 4, half-maximal inhibitory concentration: > 10000 nM
Compound 4 gave a limit, no number; the forecaster's own chance of this, stated with the estimate: 35%; middle value at least 5.0-fold (0.69 log units) away from the limit.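

Compound 2 and compound 4 both stand only as limits, so no step can be read between them: the limit of > 10000 nM in this assay, at which 2 of the 4 values shown sit.

The compounds shown leave open whether methoxycarbonyl in place of ethyl on a double-bonded chain carbon bound to a double-bonded chain carbon changes inhibition at all.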